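The source may report more compounds than this note shows. Statements on the series, on what has been measured and on what is new or still open speak of the compounds shown alone.

Compound 2 `Fc1ccc(-c2cn3ccnc3c(-c3ccc4ncn(C5CCCCC5)c4c3)n2)cc1` gives 3.5% in a functional assay on LOX IMVI cells (Homo sapiens) for inhibition, read by sulforhodamine B assay, with a stated time of 48 h, tested at 10 uM (on this read-out higher numbers stand for more inhibition at the one concentration tested (going by the name of the read-out) and lower numbers for less inhibition), and on the numbers shown it stands lowest of the two measured, with compound 1 `c1ccc2c(-c3cn4ccnc4c(-c4ccc5ncn(C6CCCCC6)c5c4)n3)cccc2c1` nearest at 7.43% in this assay, a gap that lies within the scatter. For the measured compounds named here, the only step measured so far is a number 3.9 percentage points lower from compound 1 to compound 2 (within the scatter), which swapped the aryl group on the shared core and moved the read-out by an amount within the scatter.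

Compound 3 `Brc1ccc(-c2cn3ccnc3c(-c3ccc4ncn(C5CCCCC5)c4c3)n2)cc1` is not yet measured in this assay. It differs from compound 2 by bromo in place of fluoro on an aromatic carbon. Going by the values given here, no measured step exchanges one halogen for another, so nothing bears directly on this change; the one step that touches the same aryl group shows a read-out that stayed essentially where it was. The change from compound 2 to compound 3 is therefore expected to be a number 1.5 percentage points higher from compound 2 to compound 3 (within the scatter), no shift beyond the scatter in this assay. For compound 3 the estimate in this assay is 5%, expected to fall between -5% and 15%.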

Compound 3, a percentage reported as inhibition, at one concentration (the size of the read-out at that concentration, not a potency): 30.7%
Beside the measured number, compound 3's estimate is 25.7 percentage points below it, outside the stated range (above it).
By their numbers in this assay, from the lowest: compounds 2 and 1 (each within the scatter of the next); then compound 3.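

In this assay, for the compounds shown here, the aromatic carbon para to a large group responds to the identity of the halogen: a number 27.2 percentage points higher from compound 2 to compound 3 (beyond the scatter), the first step to pass beyond the scatter, and it comes from exchanging one heavy atom for another with no change in ring, donor, acceptor or charge count. The aryl exchange now also reads differently, since a number 23.3 percentage points higher from compound 1 to compound 3 (beyond the scatter), so 4-bromophenyl separates from naphthalen-1-yl where 4-fluorophenyl did not, and compound 3 stands highest of the three with both of its steps beyond the scatter. No measurement at hand accounts for this difference between the bromo and fluoro compounds.

Two halogens cannot show whether the read-out climbs steadily along the halogen series or is particular to bromo, and chloro or iodo at this same position would separate those readings, as would a non-halogen such as methyl or an amine. On these data alone, the read-out also comes from one concentration, so whether the gain for compound 3 reflects a real difference in potency remains open.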